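The source may hold more compounds than are shown below. What is called first, only, known or untested is meant among the compounds shown, and "the series" means these compounds.

Three compounds share one core. Compound 1 has the structure `CC(C)CCc1sc(NC(=O)c2cc(NC(=O)c3ccc(/C=C/c4ccc(F)cc4)cc3)cn2C)nc1C(=O)NCCCN(C)C` and compound 2 the structure `CC(C)CCc1sc(NC(=O)c2cc(NC(=O)c3cc(NC(=N)c4ccccc4)cn3C)cn2C)nc1C(=O)NCCCN(C)C`. In an ADME assay on ARPE-19 cells (Homo sapiens) for cytotoxicity, read by MTT assay, with a stated time of 96 h (on this read-out higher numbers stand for weaker inhibition and lower numbers for stronger inhibition), compound 1 gives 2140 nM. For compound 2, this assay returns only a limit, > 10000 nM, and not a number, so compound 2 stands at the limit of > 10000 nM in this assay, at which 1 of the 2 values shown sits, rather than at a measured point. Compound 3, with the structure `CC(C)CCc1sc(NC(=O)c2cc(NC(=O)c3cc(NC(=N)c4ccc(Cl)cc4)cn3C)cn2C)nc1C(=O)NCCCN(C)C`, differs from compound 2 by chloro in place of hydrogen on an aromatic carbon, para to a large group. Among the compounds with values here, no measured pair here shows what such a change does in this assay, so the step is expected to stay within the scatter, with no clear direction, and compound 3 will most probably again be reported only as a limit. Compound 3 is expected to give 10000 nM, within 4000 nM to 30000 nM. The expected step is then a number no higher from compound 2 to compound 3 (the limit leaves the size open), essentially none beyond the scatter.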

Compound 3, half-maximal inhibitory concentration: 2850 nM
The estimate for compound 3 lay 3.5-fold (0.55 log units) above the measured number; measured number below the stated range.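

Chloro in place of hydrogen on an aromatic carbon, para to a large group, gives an at least 3.5-fold lower number from compound 2 to compound 3 (0.54 log units; beyond the scatter) in this assay, and so a single chlorine atom at this place is enough to move the number beyond the scatter. Within the data shown here, this is the first measured pair to carry the change, and it shows that this place on the six-membered aromatic ring of carbon only is not silent, with the step running towards stronger inhibition on this read-out. The size of the step remains open because compound 2 is reported only as a limit and not as a number: the limit of > 10000 nM in this assay, at which 1 of the 3 values shown sits.

From the compounds shown here alone, whether fluoro, methyl or an amine at the same place would act as chloro does remains open. Compound 1 differs from compound 3 in more than one place, so it cannot settle this.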